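From an Ethyl to a Thiophene on the Shared Core

The source may report more compounds than this note shows. Statements on the series, on what has been measured and on what is new or still open speak of the compounds shown alone.

Measured so far:
Compound 1 `O=C(Nc1cc(C(F)(F)F)cc(C(F)(F)F)c1)c1cnc(C(F)(F)F)nc1C(F)(F)F` gives > 10000 nM, which is a limit of the assay rather than a number.
Compound 2 `O=C(Nc1cc(C(F)(F)F)cc(C(F)(F)F)c1)c1cnc(F)nc1C(F)(F)F` gives 400 nM.
Compound 3 `CCc1nc(Cl)ncc1C(=O)Nc1cc(C(F)(F)F)cc(C(F)(F)F)c1` gives 400 nM.

All three were tested in an assay on Jurkat cells for activation of nuclear factor NF-kappa-B complex (Homo sapiens); on this read-out higher numbers stand for weaker inhibition and lower numbers for stronger inhibition. Among the compounds with values here, compound 1 sits at a limit, so it is known only that its value lies beyond the range of the measurement (the limit of > 10000 nM in this assay, at which 1 of the 3 values shown sits). Within the data shown here, the one step between measured compounds that differ in a single place is an at least 25-fold lower number from compound 1 to compound 2 (1.39 log units; beyond the scatter). Compound 3 stands level with compound 2 at the digits given, within the usual scatter, so no order between the two can be read.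

Compound 4 `O=C(Nc1cc(C(F)(F)F)cc(C(F)(F)F)c1)c1cnc(Cl)nc1-c1cccs1` comes from compound 3 by thiophen-2-yl in place of ethyl on an aromatic carbon. Among the measured compounds shown here, no measured step touches this position: the only step on record, from compound 1 to compound 2, concerns a trifluoromethyl turned into a fluoro elsewhere on the core, and says nothing about the ethyl or about a thiophen-2-yl. With no guidance on this change, the expected step is no change at the digits printed from compound 3 to compound 4 (within the scatter), with wide uncertainty in either direction. Compound 4 is therefore estimated at 400 nM, within a range from 60 nM to 3000 nM.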

Compound 4, half-maximal inhibitory concentration: 9800 nM
Compound 4: middle estimate off by 25-fold (1.39 log units), on the low side, outside the stated range (above it).
By their numbers in this assay, from the lowest: compounds 2 and 3 (each within the scatter of the next); then compound 4. At a limit, above all of these: compound 1.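

In this assay, thiophen-2-yl in place of ethyl on this aromatic carbon, next to the ring nitrogen, brings a 25-fold higher number from compound 3 to compound 4 (1.39 log units; beyond the scatter). Within the data shown here, the earlier step showed only that a change at another place on the shared core can matter; this one shows that the group at this place matters too, and that here the swap from a small open chain to a five-membered aromatic ring goes with weaker inhibition. Compound 4 still gives a number, while compound 1 rests at a limit of the assay: the limit of > 10000 nM in this assay, at which 1 of the 4 values shown sits.

With only these two groups compared at this place while the rest of the molecule stays the same, a single step cannot tell whether the ring itself, its sulfur or simply the larger number of heavy atoms goes with the weaker inhibition. A methyl, a longer chain, a phenyl ring or an amine on this carbon would help to separate these possibilities and show whether other groups here can match or pass the ethyl of compound 3.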